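This account rests on a few compounds, and the source may have more. Where it says the series, first, only, none or still open, it means among the compounds named here.

For the measured compounds named here, in an assay on HEK293 cells for displacement of a labelled ligand from NPC1-like intracellular cholesterol transporter 1 (Homo sapiens) (on this read-out higher numbers stand for weaker inhibition and lower numbers for stronger inhibition), compound 2 `CCOC(=O)C1CCN(C(=O)CN2CN(c3ccccc3)C3(CCN(C(=O)c4ccc(C5CCCCC5)cc4)CC3)C2=O)CC1` gives 900 nM, the lowest of the numbers measured so far. Compound 3 `CC(C)(C)OC(=O)NCC1CCCN(C(=O)CN2CN(c3ccccc3)C3(CCN(C(=O)c4ccc(C5CCCCC5)cc4)CC3)C2=O)C1` gives 3800 nM in this assay, a higher number whose gap from compound 2 lies beyond the usual scatter. Compound 1 `CC(C)(C)OC(=O)NCCCCNC(=O)CN1CN(c2ccccc2)C2(CCN(C(=O)c3ccc(C(C)(C)C)cc3)CC2)C1=O` gives "not determined" (no result reported) in this assay, so no result is available for it. Compound 4 `CC1(C)CC(OC(=O)CN2CN(c3ccccc3)C3(CCN(C(=O)c4ccc(C5CCCCC5)cc4)CC3)C2=O)CC(C)(C)N1` has not yet been measured, and it differs from compound 2 by (2,2,6,6-tetramethylpiperidin-4-yl)oxy in place of 4-(ethoxycarbonyl)piperidin-1-yl on a carbonyl carbon. Going by the values given here, no measured pair shows a change of this kind, so the direction cannot be read from the data. The expected step in this assay is small, if anything towards a slightly higher number, and is estimated as a 1.7-fold higher number from compound 2 to compound 4 (0.22 log units; within the scatter). Compound 4 is therefore expected to give about 1500 nM in this assay, with a likely range from 400 nM to 6000 nM.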

Compound 4, half-maximal inhibitory concentration: 600 nM
The estimate for compound 4 lay 2.5-fold (0.40 log units) above the measured number; low and high end bracket the measured number.
By their numbers in this assay, from the lowest: compounds 4 and 2 (each within the scatter of the next); then compound 3.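

On the carbonyl carbon, (2,2,6,6-tetramethylpiperidin-4-yl)oxy in place of 4-(ethoxycarbonyl)piperidin-1-yl gives a 1.5-fold lower number from compound 2 to compound 4 (0.18 log units; within the scatter) in this assay and so leaves the number unchanged within the scatter. This single comparison at this place shows that the two groups cannot be told apart on this read-out, even though only the entering group carries a hydrogen-bond donor. No measurement shown here accounts for this result. On these data alone, whether a carboxylic acid or a simple open-chain amine on the same carbonyl carbon would move the number beyond the scatter remains open.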